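This account rests on a few compounds, and the source may have more. Where it says the series, first, only, none or still open, it means among the compounds named here.

In a functional assay on A549 cells (Homo sapiens) for inhibition, read by CCK-8 assay, with a stated time of 72 h, tested at 10 uM (a lower number here means less inhibition of growth, a higher number more inhibition of growth at the concentration tested), compound 2 `Cc1ccc(NC(=O)C2(C(=O)Nc3ccc(Nc4ncc5cc(C(=O)N(C)C)n(C6CCCC6)c5n4)cc3)CC2)cc1` gives 90.6%, level within the scatter with compound 1 `CN(C)C(=O)c1cc2cnc(Nc3ccc(NC(=O)C4(C(=O)Nc5cccc(F)c5)CC4)cc3)nc2n1C1CCCC1` at 91.8%. Compound 3 `COc1cccc(NC(=O)C2(C(=O)Nc3ccc(Nc4ncc5cc(C(=O)N(C)C)n(C6CCCC6)c5n4)cc3)CC2)c1` carries 3-methoxyphenyl in place of 4-methylphenyl on an amide-type nitrogen. Among the measured compounds shown here, only one measured step bears on this change, a replacement on the same amide-type nitrogen that gave a number 1.2 percentage points lower from compound 1 to compound 2 (within the scatter). With that single small step as the guide, no step beyond the scatter is expected in this assay. The estimated value for compound 3 is 90%, with an expected range of 81% to 97%. This estimate means an expected a number 0.6 percentage points lower from compound 2 to compound 3 (within the scatter).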

Compound 3, percent growth inhibition at one concentration: 96%
The estimate for compound 3 lay 6 percentage points below the measured number; measured number inside the range.
By their numbers in this assay, from the lowest: compounds 2, 1 and 3 (each within the scatter of the next).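

In this assay, the change to 3-methoxyphenyl on the amide-type nitrogen gives a number 5.4 percentage points higher from compound 2 to compound 3 (within the scatter), and methoxy in place of fluoro on an aromatic carbon gives a number 4.2 percentage points higher from compound 1 to compound 3 (within the scatter). This place has therefore now taken a group with one hydrogen-bond acceptor, and neither step leaves the scatter. No evidence is available to explain these readings.

Going by these compounds, whether an amine or a carboxylic acid on this phenyl ring would give a step beyond the scatter remains open. So does the effect of replacing the phenyl ring with cyclohexyl.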